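This account rests on a few compounds, and the source may have more. Where it says the series, first, only, none or still open, it means among the compounds named here.

Three compounds that share one core and differ only in the group on a sulfonyl sulfur have been measured in an ADME assay on microsomes from liver (Homo sapiens) for pharmacokinetics, read by LC-MS, with a stated time of 60 min, tested at 1 uM; a higher number here means faster removal of the compound, a lower number slower removal. Compound 1 `O=C(NCc1ccc(S(=O)(=O)c2ccccc2)cc1)N1Cc2ccncc2C1` gives 7.5 mL/min/kg. Compound 2 `O=C(NCc1ccc(S(=O)(=O)C2CCOCC2)cc1)N1Cc2ccncc2C1` gives 6 mL/min/kg. Compound 3 `O=C(NCc1ccc(S(=O)(=O)N2CCC[C@H](O)C2)cc1)N1Cc2ccncc2C1` gives 8 mL/min/kg. Compound 2 stands with the lowest of the three numbers, though its two neighbours sit close to it: a 1.3-fold lower number from compound 1 to compound 2 (0.10 log units; within the scatter), and a 1.3-fold higher number from compound 2 to compound 3 (0.12 log units; within the scatter). The remaining pair is no wider: a 1.1-fold higher number from compound 1 to compound 3 (0.03 log units; within the scatter).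

Compound 4 `CN1CCN(S(=O)(=O)c2ccc(CNC(=O)N3Cc4ccncc4C3)cc2)CC1` keeps the same core and differs from compound 2 in one place: 4-methylpiperazin-1-yl in place of oxan-4-yl on a sulfonyl sulfur. Among the measured compounds shown here, the steps that bear on this change are the three just given, all of them exchanges of the group on a sulfonyl sulfur, and each of them stays within the scatter. For compound 4 no step beyond the scatter is therefore expected in this assay: a 1.2-fold higher number from compound 2 to compound 4 (0.07 log units; within the scatter). Compound 4 is estimated at 7 mL/min/kg, with a range from 4 mL/min/kg to 13 mL/min/kg.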

Compound 4, clearance: 9 mL/min/kg
For compound 4 the middle estimate is 1.3-fold (0.11 log units) below the measured one; the measured number falls inside the stated range.
By their numbers in this assay, from the lowest: compounds 2, 1, 3 and 4 (each within the scatter of the next).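

The 4-methylpiperazin-1-yl group, with two nitrogens in its ring, extends the series on a sulfonyl sulfur to a fourth six-membered ring, and in this assay no exchange involving it leaves the scatter (a 1.5-fold higher number from compound 2 to compound 4 (0.18 log units; within the scatter)), (a 1.1-fold higher number from compound 3 to compound 4 (0.05 log units; within the scatter)), (a 1.2-fold higher number from compound 1 to compound 4 (0.08 log units; within the scatter)). Across the phenyl, oxan-4-yl, 3-hydroxypiperidin-1-yl and 4-methylpiperazin-1-yl groups, the four compounds therefore cannot be separated by this read-out. Nothing available explains the result.

From the compounds shown here alone, whether a group of another kind on the sulfonyl sulfur, such as a carboxylic acid, a primary amine or a longer alkyl chain, would produce a step beyond the scatter remains open. Also open, going by these compounds, is whether changes elsewhere on the shared core would shift the number more than these exchanges do.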